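Styryl oxadiazole sulfonamides: cytotoxicity notes toward compound 3

This account rests on a few compounds, and the source may have more. Where it says the series, first, only, none or still open, it means among the compounds named here.

Measured so far:
- compound 1 `CC(C)(O)c1cn(Cc2nnc(-c3cc(S(N)(=O)=O)c(SCc4ccccc4)cc3Cl)o2)nn1` gives 82000 nM in a functional assay on HCT-116 cells (Homo sapiens) for cytotoxicity, read by MTT assay, with a stated time of 72 h; on this read-out higher numbers stand for weaker inhibition and lower numbers for stronger inhibition
- compound 2 `NS(=O)(=O)c1cc(-c2nnc(/C=C/c3cccc(Cl)c3)o2)c(Cl)cc1SCc1ccccc1` gives 12000 nM in this assay

For the measured compounds named here, compound 2 holds the lowest of the two numbers in this assay; the single measured step, a 6.8-fold lower number from compound 1 to compound 2 (0.83 log units; beyond the scatter), separates it from compound 1 and is the only comparison available.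

Compound 3 `NS(=O)(=O)c1cc(-c2nnc(/C=C/c3ccc(Br)cc3)o2)c(Cl)cc1SCc1ccccc1` is the next member. It differs from compound 2 by 4-bromophenyl in place of 3-chlorophenyl on a double-bonded chain carbon bound to a double-bonded chain carbon. Going by the values given here, no measured step bears on this kind of change: the one step recorded, a 6.8-fold lower number from compound 1 to compound 2 (0.83 log units; beyond the scatter), swaps a whole side chain for the styryl unit, whereas here the styryl unit is kept and only the halogen and its ring substitution change. With nothing to argue for a shift, the expectation for this assay is no step beyond the scatter, so compound 3 is estimated at 12000 nM, with a range from 4000 nM to 36000 nM, which amounts to an expected step of no change at the digits printed from compound 2 to compound 3 (within the scatter).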

Compound 3, half-maximal inhibitory concentration: 15000 nM
Compound 3: the middle estimate sits 1.3-fold (0.10 log units) below what was measured; low and high end bracket the measured number.
By their numbers in this assay, from the lowest: compounds 2 and 3 (each within the scatter of the next); then compound 1.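

In this assay the exchange of 3-chlorophenyl for 4-bromophenyl gives a 1.3-fold higher number from compound 2 to compound 3 (0.10 log units; within the scatter) and so leaves the number within the scatter, which means that this position accepts both halogenated phenyl groups without a readable change, although halogen and ring substitution change together here. The side-chain comparison now rests on two styryl members and not one: a 6.8-fold lower number from compound 1 to compound 2 (0.83 log units; beyond the scatter) is joined by a 5.5-fold lower number from compound 1 to compound 3 (0.74 log units; beyond the scatter) and both steps lie beyond the scatter, so 2-(3-chlorophenyl)ethenyl and 2-(4-bromophenyl)ethenyl each stand apart from the (4-(1-hydroxy-1-methylethyl)-1H-1,2,3-triazol-1-yl)methyl group of compound 1. No supporting data are available to explain either the flat step or the two larger ones.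

The compounds shown leave open whether the identity of the halogen and its place on the ring would each matter if changed alone, and whether a phenyl ring carrying an amine or a carboxylic acid in place of halogen would stay at the same level. Also open, on these data alone, is whether any change on the shared core would move the number further than the side-chain exchange does.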